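Fluorostilbenes and the second fluoro on the ring

The source may report more compounds than this note shows. Statements on the series, on what has been measured and on what is new or still open speak of the compounds shown alone.

Measured so far:
compound 1 `Fc1ccccc1/C=C/c1ccccc1` 700 nM
compound 2 `Fc1cccc(F)c1/C=C/c1ccccc1` 6900 nM
compound 3 `Fc1ccc(/C=C/c2cccc(F)c2)cc1` 650 nM

All three were run in an assay on HepG2 cells for activation of nuclear factor erythroid 2-related factor 2 (Homo sapiens), read by a luciferase reporter, with a stated time of 5 h; a lower number here means that less compound is needed, a higher number that more compound is needed for the effect. Compound 1 and compound 3 sit within the scatter of each other, so nothing separates them; compound 2 stands apart, with the largest gap to compound 3.

Compound 1 and compound 2 differ in one place, (fluoro in place of hydrogen on an aromatic carbon). The step is a 9.9-fold higher number from compound 1 to compound 2 (0.99 log units; beyond the scatter), a modest step but beyond the scatter.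

Compound 3 and compound 1 differ in more than one place; the difference between the two cores is not broken down here.

Compound 4 `Fc1cccc(/C=C/c2ccc(F)cc2F)c1` has not been measured. It differs from compound 3 in one place, (fluoro in place of hydrogen on an aromatic carbon). This is the same kind of change as from compound 1 to compound 2: in both the entering fluoro sits meta to a fluoro group, but in compound 4 it is ortho to a group of 9 heavy atoms, whereas in compound 2 it is ortho to a group of 8 heavy atoms. The two cores themselves differ, so the parallel is not exact.

Among the measured compounds shown here, for compound 4 in this assay the expected step is a 7.7-fold higher number from compound 3 to compound 4 (0.89 log units; beyond the scatter), resting on the single earlier instance, compound 1 to compound 2, where the step was a 9.9-fold higher number from compound 1 to compound 2 (0.99 log units; beyond the scatter). That step rests on one pair, and the core differs. The range is kept wide. The estimate for compound 4 is 5000 nM, between 1500 nM and 16000 nM.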

Compound 4, half-maximal effective concentration: 450 nM
Estimate against measurement, compound 4: 11-fold (1.05 log units) above, and the stated range ends above it.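

Working notes on carrying the fluoro change between cores. In this assay, placing fluoro on the aromatic carbon of the second core gives a 1.4-fold lower number from compound 3 to compound 4 (0.16 log units; within the scatter), so no shift can be read on this core. Set beside the earlier pair, the same replacement does not carry over at the same size, and the two steps are clearly separate: the same change on two cores in this assay, a 9.9-fold higher number (0.99 log units; beyond the scatter) from compound 1 to compound 2 and a 1.4-fold lower number (0.16 log units; within the scatter) from compound 3 to compound 4, 14-fold (1.15 log units) apart, beyond the scatter of two such steps

This shows that the step seen on the core of compound 1 cannot be applied as a fixed increment to other cores in this series; the replacement must be judged core by core. It does not show which feature of the cores separates the two results, as they differ in more than one place, and two pairs establish no trend in either direction.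

The compounds shown leave open whether a group other than fluoro on the same aromatic carbon, such as methoxy, an amine or a carboxylic acid, would follow the step on the first core, the step on the second, or neither. Also open, going by these compounds, is whether the same fluoro replacement on a third core would give a large step or one within the scatter.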